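Swapping the Aryl End: Expected Effect on Cell Toxicity

The source may hold more compounds than are shown below. What is called first, only, known or untested is meant among the compounds shown, and "the series" means these compounds.

Compound 1 `COc1cc(NC(C)CCCNC(=O)NNC(=O)/C(C)=C/c2ccccc2)c2ncccc2c1` — 36500 nM
Compound 2 `COc1cc(NC(C)CCCNC(=O)NNC(=O)/C=C/c2ccc(OC)c(OC)c2)c2ncccc2c1` — 37000 nM

In an ADME assay on L6 cells (Rattus norvegicus) for cytotoxicity, read by resazurin assay, with a stated time of 70 h (on this read-out lower numbers stand for stronger inhibition and higher numbers for weaker inhibition), compound 2 gives 37000 nM, the highest of the two numbers, with compound 1 closest at 36500 nM. Compound 3 `COc1cc(NC(C)CCCNC(=O)NNC(=O)/C=C/c2ccc(Cl)cc2)c2ncccc2c1` differs from compound 2 by 4-chlorophenyl in place of 3,4-dimethoxyphenyl on a double-bonded chain carbon bound to a double-bonded chain carbon. Within the data shown here, the one step measured so far, a 1.0-fold higher number from compound 1 to compound 2 (0.01 log units; within the scatter), also changed the group at this same end of the chain, and the number barely moved. On that basis the number for compound 3 is expected to stay close to that of compound 2, with a step of no change at the digits printed from compound 2 to compound 3 (within the scatter). The estimated value for compound 3 is 37000 nM, within a range of 18000 nM to 75000 nM.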

Compound 3, half-maximal inhibitory concentration: 7300 nM
For compound 3 the middle estimate is 5.1-fold (0.70 log units) above the measured one; measured number outside the range, below it.
By their numbers in this assay, from the lowest: compound 3; then compounds 1 and 2 (each within the scatter of the next).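

The group at this end of the chain can matter after all: in this assay the swap from 3,4-dimethoxyphenyl to 4-chlorophenyl gives a 5.1-fold lower number from compound 2 to compound 3 (0.70 log units; beyond the scatter) and the wider change to 2-(4-chlorophenyl)ethenyl gives a 5.0-fold lower number from compound 1 to compound 3 (0.70 log units; beyond the scatter) as well. The matching numbers of compound 1 and compound 2 therefore did not mean that every aryl end behaves alike. Nothing at hand explains this drop.

As far as these compounds go, whether the chlorine itself sets the lower number stays open. An unsubstituted phenyl, a 4-fluorophenyl or a 4-methoxyphenyl at this place could begin to settle that.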